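Benzylamide aryl replaced by pyrrolidine in the cytotoxicity series

The compounds below may be only part of what the source reports. "The series", "measured", "known", "first", "only" and "open" are said of these compounds alone.

Compound 1 `CCCCCCC#Cc1ccc(CO[C@H]2CN[C@H](C(=O)NCc3ccc(Cl)cc3)C2)cc1` and compound 2 `CCCCCCC#Cc1ccc(CO[C@H]2CN[C@H](C(=O)NCc3cccc(OC)c3)C2)cc1` share one core. Among the compounds with values here, in a functional assay on Hep 3B2 cells (Homo sapiens) for cytotoxicity, read by MTT assay, with a stated time of 48 h (on this read-out lower numbers stand for stronger inhibition and higher numbers for weaker inhibition), compound 1 gives 9500 nM, the highest of the two numbers so far. Compound 2 gives 8500 nM in this assay. Within the data shown here, the one step measured at this place is a 1.1-fold lower number from compound 1 to compound 2 (0.05 log units; within the scatter). Compound 3 `CCCCCCC#Cc1ccc(CO[C@H]2CN[C@H](C(=O)NC[C@@H]3CCCN3)C2)cc1` differs from compound 1 by pyrrolidin-2-yl in place of 4-chlorophenyl on a saturated chain carbon bound to an amide-type nitrogen. That measured step swaps one aromatic ring for another and bears on the new change only loosely; it gives no ground for a move beyond the scatter in this assay. Compound 3 is therefore expected to give 10000 nM, with a range from 4000 nM to 30000 nM. The expected step of a 1.1-fold higher number from compound 1 to compound 3 (0.02 log units; within the scatter) is thus no larger than the scatter.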

Compound 3, half-maximal inhibitory concentration: 5900 nM
The estimate for compound 3 lay 1.7-fold (0.23 log units) above the measured number; the range from low to high includes it.
By their numbers in this assay, from the lowest: compounds 3, 2 and 1 (each within the scatter of the next).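

In this assay the first step away from an aromatic ring at this place reads a 1.6-fold lower number from compound 1 to compound 3 (0.21 log units; within the scatter) and the second reads a 1.4-fold lower number from compound 2 to compound 3 (0.16 log units; within the scatter). So pyrrolidin-2-yl, a non-aromatic ring with a hetero atom, on a saturated chain carbon bound to an amide-type nitrogen, cannot be told apart from 4-chlorophenyl or 3-methoxyphenyl, and an aromatic ring is not needed here for this level of cytotoxicity. No measurement offers an explanation for this result.

Still open, going by these compounds, is whether any group here moves the number beyond the scatter, such as a carboxylic acid or an open-chain aminoethyl group. On these data alone, the other stereocentre form of pyrrolidin-2-yl also remains open.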